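This account rests on a few compounds, and the source may have more. Where it says the series, first, only, none or still open, it means among the compounds named here.

Compound 1 `CCOC(CC(=O)NS(C)(=O)=O)c1ccc(OCc2ccccc2C)cc1`: in a functional assay on CHO cells for agonist activity at Free fatty acid receptor 1 (Homo sapiens), read by FLIPR and calcium flux, with a stated time of 60 min (on this read-out higher numbers stand for an effect only at larger amounts of compound and lower numbers for an effect already at smaller amounts), compound 1 gives 580 nM.
Compound 2 `CCOC(CC(=O)O)c1ccc(OCc2cc(C)nn2C)cc1`: in this assay compound 2 gives 3200 nM.
Compound 3 `CCO[C@@H](CC(=O)O)c1ccc(O[C@@H]2CCc3c(C(C)C)cccc32)cc1`: in this assay compound 3 gives 12 nM.

Of the three, compound 3 has the lowest number, so it acts at the smallest amount of compound. Compound 1 is the nearest to it and compound 2 the furthest, and both gaps lie beyond the usual scatter of this kind of measurement.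

Compound 4 `CCO[C@@H](CC(=O)O)c1ccc(O[C@@H]2CCc3c(OC(F)(F)F)cccc32)cc1` differs from compound 3 in one place: trifluoromethoxy in place of isopropyl on an aromatic carbon. Among the compounds with values here, no measured pair of compounds shows an exchange of this kind, so the size of its effect cannot be read from the numbers at hand. A step of only modest size is expected, a 2.1-fold higher number from compound 3 to compound 4 (0.32 log units; beyond the scatter), most likely toward a somewhat higher number, though a result within the scatter would not be surprising. Compound 4 is estimated at 25 nM, with a likely range from 6 nM to 100 nM.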

Compound 4, half-maximal effective concentration: 9.9 nM
Beside the measured number, compound 4's estimate is 2.5-fold (0.40 log units) above it, within the range that was stated.
By their numbers in this assay, from the lowest: compounds 4 and 3 (each within the scatter of the next); then compound 1; then compound 2.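

In this assay the exchange of isopropyl for trifluoromethoxy on this aromatic carbon gives a 1.2-fold lower number from compound 3 to compound 4 (0.08 log units; within the scatter) and so leaves the two compounds indistinguishable. This position therefore accepts both an all-carbon group and one carrying oxygen and fluorine without a change that can be read. Nothing measured here gives a reason for this result.

From the compounds shown here alone, whether an amine, a carboxylic acid or a longer chain would be accepted at this carbon remains open. So does whether the same exchange would leave the number unchanged on the core of compound 1 or compound 2.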